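The compounds below may be only part of what the source reports. "The series", "measured", "known", "first", "only" and "open" are said of these compounds alone.

Compound 1 `COc1ccc(Cc2coc3cccc(O)c3c2=O)cc1` stands at the edge of what a functional assay on H9c2 cells (Mus musculus) for cytotoxicity against H9c2 (Rattus norvegicus), read by MTT assay, with a stated time of 24 h (a higher number here means that more compound is needed for the effect, a lower number that less compound is needed), can report: in this assay compound 1 gives > 100000 nM, which is a limit of the assay and not a number. Compound 2 `COc1ccc(Cc2coc3cc(OC)cc(OC)c3c2=O)cc1` likewise gives only a limit in this assay, > 100000 nM. Compound 3 `COc1cc(OC)c2c(=O)c(Cc3ccc(C(F)(F)F)cc3)coc2c1` also gives a limit in this assay, > 100000 nM. The step that the two limits leave unreadable from compound 2 to compound 3 cannot be read because of the limit of > 100000 nM in this assay, at which 3 of the 3 values shown sit. Compound 4 `CCC(=O)Oc1cc(O)c2c(=O)c(Cc3ccc(OC)cc3)coc2c1` differs from compound 1 by propanoyloxy in place of hydrogen on an aromatic carbon. Going by the values given here, no measured step bears on this change, and none of the three measured compounds gives a number to anchor it. Compound 4 is therefore expected to sit at the limit as well, with an estimate of 100000 nM between 30000 nM and 300000 nM. The expected step is then a number no higher from compound 1 to compound 4 (the limit leaves the size open), of no readable size.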

Compound 4, half-maximal effective concentration: > 100000 nM
Compound 4 was reported as a limit (the forecaster's own chance of this, stated with the estimate: 80%); the middle value sits exactly at the limit.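

No step from compound 1 to compound 4 can be read, because both sit at the same limit of the assay: the limit of > 100000 nM in this assay, at which 4 of the 4 values shown sit.

From the compounds shown here alone, whether propanoyloxy in place of hydrogen changes anything in this assay, and how these four compounds truly rank, stays open.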